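Ester Variation on a Dihydropyrimidinone Adenosine Binder

The source may report more compounds than this note shows. Statements on the series, on what has been measured and on what is new or still open speak of the compounds shown alone.

Measured compounds:
- compound 1, `CC1=C(C(=O)OC(C)(C)C)C(c2ccoc2)NC(=O)N1`: 4440 nM
- compound 2, `CC1=C(C(=O)OC(C)C)C(c2ccsc2)NC(=S)N1`: 315 nM

In an assay on membranes from HEK293 cells for displacement of a labelled ligand from adenosine receptor A2b (Homo sapiens), read by scintillation counting, with a stated time of 30 min (a higher number here means a weaker inhibitor, a lower number a stronger inhibitor), compound 1 gives 4440 nM, the highest of the two numbers recorded, which means it is the weaker inhibitor of the pair. Compound 2, `CC1=C(C(=O)OC(C)C)C(c2ccsc2)NC(=S)N1`, differs from compound 1 in several places at once, so the two values only show that compound 2 sits well beyond the scatter on the stronger side.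

Compound 3, `CC1=C(C(=O)OC2CCC2)C(c2ccoc2)NC(=O)N1`, has not been measured. It differs from compound 1 in one place: cyclobutyl in place of tert-butyl on an oxygen next to a carbonyl group. For the measured compounds named here, nothing among the measured compounds isolates a change of this kind, and the group that leaves and the group that enters are of the same size, so no step beyond the usual scatter in this assay is expected in either direction. The estimated step from compound 1 to compound 3 is a 1.3-fold lower number from compound 1 to compound 3 (0.10 log units; within the scatter). Compound 3 is therefore expected to give about 3500 nM in this assay, with a likely range from 1200 nM to 10000 nM.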

Compound 3, inhibition constant: 307 nM
Compound 3: the middle estimate sits 11-fold (1.06 log units) above what was measured, outside the stated range (below it).
By their numbers in this assay, from the lowest: compounds 3 and 2 (each within the scatter of the next); then compound 1.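

In this assay, the group on this ester oxygen proves able to move the result well beyond the scatter: the step is a 14-fold lower number from compound 1 to compound 3 (1.16 log units; beyond the scatter) even though tert-butyl and cyclobutyl have the same count of heavy atoms, all carbon, and neither brings a hydrogen-bond donor, a hydrogen-bond acceptor or a net charge. Of the differences counted between the two groups, only the ring remains, since cyclobutyl holds a four-membered non-aromatic ring of carbon only and tert-butyl holds no ring, so for this one pair the ring goes with the lower number. No measurement shown here explains the size of this step.

On these data alone, whether the lower number follows from having a ring at all or from this particular ring stays open, and a cyclopropyl group, a cyclopentyl group or a straight butyl chain on the same oxygen would help to separate those readings. For the compounds shown here, compound 2 differs from compound 1 and compound 3 in several places, so no step to it can be read.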